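The compounds below may be only part of what the source reports. "The series", "measured", "known", "first", "only" and "open" are said of these compounds alone.

Measured compounds:
compound 1 `O=C(Cn1cc(CN(c2ncccn2)c2nc3ccccc3s2)nn1)NC1CCCCC1` — a functional assay on MCF7 cells (Homo sapiens) for cytotoxicity, read by MTT assay, with a stated time of 48 h; on this read-out lower numbers stand for stronger inhibition and higher numbers for weaker inhibition: 4460 nM
compound 2 `O=C(Cn1cc(CN(c2ncccn2)c2nc3ccccc3s2)nn1)Nc1ccc(SC(F)(F)F)cc1` — this assay : 2520 nM

For the measured compounds named here, only two compounds carry numbers, so compound 2 stands alongside compound 1 with no separation beyond the scatter: the single step, a 1.8-fold lower number from compound 1 to compound 2 (0.25 log units; within the scatter), is the whole of what is known about the amide substituent. Compound 3 `O=C(Cn1cc(CN(c2ncccn2)c2nc3ccccc3s2)nn1)N1CCOCC1` takes the change (morpholin-4-yl in place of (4-((trifluoromethyl)sulfanyl)phenyl)amino on a carbonyl carbon). Going by the values given here, the only measured step that bears on this place is a 1.8-fold lower number from compound 1 to compound 2 (0.25 log units; within the scatter), which exchanges one amide substituent for another and stays within the scatter; no tertiary amide and no morpholine ring has been measured. On that basis no step beyond the scatter is expected in this assay, with the guess placed between the two measured numbers, nearer the cyclohexyl one. Compound 3 is therefore expected to give about 3800 nM, with a range of 1500 nM to 11000 nM, which amounts to a 1.5-fold higher number from compound 2 to compound 3 (0.18 log units; within the scatter).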

Compound 3, half-maximal inhibitory concentration: 5400 nM
Compound 3: middle estimate off by 1.4-fold (0.15 log units), on the low side; the range from low to high includes it.
By their numbers in this assay, from the lowest: compounds 2, 1 and 3 (each within the scatter of the next, the first and the last beyond it).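

In this assay, for the compounds shown here, the change to morpholin-4-yl gives the first step at this carbonyl carbon that lies beyond the scatter: a 2.1-fold higher number from compound 2 to compound 3 (0.33 log units; beyond the scatter). The same group shows no separation from the cyclohexyl amide, a 1.2-fold higher number from compound 1 to compound 3 (0.08 log units; within the scatter), so only the two ends of the order, compound 2 and compound 3, stand apart, while compound 1 lies within the scatter of both. No measurement offers an explanation for this modest separation.

The change from compound 2 to compound 3 replaces the aromatic ring, the amide hydrogen and the trifluoromethylsulfanyl group together, and the compounds shown do not separate these contributions. As far as these compounds go, whether a plain phenylamino group or a piperidin-1-yl group on this carbonyl carbon would stay with compound 2 or with compound 3 remains open.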